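A few compounds are considered here, and "the series" means these few. Any claim that something is new, unique, unknown or untested is made for them only; others in the source may bear on it.

Measured in an ADME assay on PBMC cells (Homo sapiens) for inhibition, read by MTT assay; on this read-out higher numbers stand for weaker inhibition and lower numbers for stronger inhibition:
- compound 1 `CC1=CCC[C@H]2[C@](C)(CC3=CC(=O)C=CC3=O)[C@@H](C)CC[C@]12C`: 4500 nM
- compound 2 `CC1CCC[C@H]2[C@](C)(CC3=CC(=O)C(Cl)=CC3=O)[C@@H](C)CC[C@]12C`: "not determined" (no result reported)

For the measured compounds named here, compound 1 holds the only number, so it cannot be ranked against any other compound. Compound 2 offers no comparison.

Compound 3 `CC1=CCC[C@H]2[C@](C)(CC3=CC(=O)C(Sc4ccccc4)=CC3=O)[C@@H](C)CC[C@]12C` keeps the core of compound 1 and carries phenylsulfanyl in place of hydrogen on a double-bonded ring carbon. Going by the values given here, no step between measured compounds is available to size this change, and the single anchor is compound 1 at 4500 nM. In this assay the working expectation is therefore no shift beyond the usual scatter, with no firm direction and a wide margin on both sides. The expected step is a 1.1-fold lower number from compound 1 to compound 3 (0.05 log units; within the scatter). For compound 3 the estimate is 4000 nM, with an expected range of 1300 nM to 12000 nM.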

Compound 3, half-maximal inhibitory concentration: 11200 nM
For compound 3 the middle estimate is 2.8-fold (0.45 log units) below the measured one; the measured number falls inside the stated range.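

In this assay, for the compounds shown here, this is the first size read for any change on the double-bonded ring carbon: phenylsulfanyl in place of hydrogen gives a 2.5-fold higher number from compound 1 to compound 3 (0.40 log units; beyond the scatter). On this read-out the modest step means weaker inhibition, so the added aromatic ring and sulfur leave the number measurable but move it in the weaker direction. Nothing available accounts for the step.

From the compounds shown here alone, with one step at this position, it stays open whether the shift follows the phenyl ring, the sulfur or simply any replacement of that hydrogen. Going by these compounds, how a methylsulfanyl group, an amine or a carboxylic acid on the same carbon would read in this assay also remains open.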